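The compounds below may be only part of what the source reports. "The series", "measured", "known", "first", "only" and "open" are said of these compounds alone.

In a functional assay on MCF7 cells (Homo sapiens) for inhibition, read by MTT assay (on this read-out lower numbers stand for stronger inhibition of growth and higher numbers for weaker inhibition of growth), compound 1 `COc1cc2oc(-c3cccc(NC(=O)c4ccccc4)c3)cc(=O)c2c(OC)c1OC` gives 12100 nM and compound 2 `COc1cc2oc(-c3cccc(NC(=O)c4ccc(F)cc4)c3)cc(=O)c2c(OC)c1OC` gives 14700 nM while compound 3 `COc1cc2oc(-c3cccc(NC(=O)c4ccc(C(F)(F)F)cc4)c3)cc(=O)c2c(OC)c1OC` gives 10600 nM on the same read-out. Compound 3 thus sits within the scatter of both other compounds, and the three values form a single level with no order among them.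

Compound 4 `COc1cccc(C(=O)Nc2cccc(-c3cc(=O)c4c(OC)c(OC)c(OC)cc4o3)c2)c1` has 3-methoxyphenyl in place of 4-(trifluoromethyl)phenyl on a carbonyl carbon with the shared core unchanged.

Going by the values given here, three measured steps bear on this change, all of them replacements on the aromatic ring held by that carbonyl. The steps of a 1.2-fold higher number from compound 1 to compound 2 (0.08 log units; within the scatter) and a 1.1-fold lower number from compound 1 to compound 3 (0.06 log units; within the scatter) and a 1.4-fold lower number from compound 2 to compound 3 (0.14 log units; within the scatter) are each within the scatter. Hydrogen, fluoro and trifluoromethyl on that ring therefore cannot be told apart in these data. Among the compounds with values here, no compound with a methoxy group has been measured yet, so the evidence for compound 4 is indirect and the range has to stay wide.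

No step beyond the scatter is expected in this assay in either direction. The estimated step is a 1.1-fold higher number from compound 3 to compound 4 (0.05 log units; within the scatter) and is expected to be small. For compound 4 the estimated value is 12000 nM with an expected range from 6000 nM to 25000 nM on this read-out.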

Compound 4, concentration for 50% growth inhibition: 7670 nM
Beside the measured number, compound 4's estimate is 1.6-fold (0.19 log units) above it; the measured number falls inside the stated range.
By their numbers in this assay, from the lowest: compounds 4, 3, 1 and 2 (each within the scatter of the next).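

In this assay, the change to 3-methoxyphenyl on a carbonyl carbon whose other neighbour is the amide-type nitrogen gives three steps that all stay within the scatter (a 1.4-fold lower number from compound 3 to compound 4 (0.14 log units; within the scatter)) and (a 1.9-fold lower number from compound 2 to compound 4 (0.28 log units; within the scatter)) and (a 1.6-fold lower number from compound 1 to compound 4 (0.20 log units; within the scatter)). The series at this position now includes an oxygen-bearing group, with a hydrogen-bond acceptor that 4-(trifluoromethyl)phenyl lacks, and a group named at the 3-position rather than the 4-position, yet hydrogen, fluoro, trifluoromethyl and methoxy still cannot be told apart on this read-out, so all four compounds remain a single level. No measurement at hand explains this flat result.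

On these data alone, whether any replacement at this position can move the number beyond the scatter remains open, for instance an amine or a carboxylic acid on that aromatic ring, or a longer chain in place of the ring. The compounds shown also leave open whether the level is set by the shared core rather than by this carbonyl-bound group, since only this one position varies among them.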